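Furan-2-yl replaces a halogenated phenyl on the pyridine core

This account rests on a few compounds, and the source may have more. Where it says the series, first, only, none or still open, it means among the compounds named here.

Compound 1 `CC(C(=O)NCc1ccc(C(F)(F)F)nc1-c1ccc(N(C)C)cc1)c1ccc(NS(C)(=O)=O)c(F)c1`, 3.2 nM; compound 2 `CC(C(=O)NCc1ccc(C(F)(F)F)nc1-c1ccc(C(C)(C)C)cc1)c1ccc(NS(C)(=O)=O)c(F)c1`, 0.5 nM; compound 3 `CC(C(=O)NCc1ccc(C(F)(F)F)nc1-c1ccc(F)c(Cl)c1)c1ccc(NS(C)(=O)=O)c(F)c1`, 0.2 nM in an assay on CHO cells for antagonist activity at transient receptor potential cation channel subfamily V member 1 (Homo sapiens), read by FLIPR; a lower number here means a stronger inhibitor, a higher number a weaker inhibitor.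

Compound 3 gives the lowest number of the three, with compound 2 nearest (a 2.5-fold lower number from compound 2 to compound 3 (0.40 log units; beyond the scatter)) and compound 1 furthest (a 16-fold lower number from compound 1 to compound 3 (1.20 log units; beyond the scatter)). Compound 4 `CC(C(=O)NCc1ccc(C(F)(F)F)nc1-c1ccco1)c1ccc(NS(C)(=O)=O)c(F)c1` differs from compound 3 by furan-2-yl in place of 3-chloro-4-fluorophenyl on an aromatic carbon. For the measured compounds named here, no measured step covers a furan at this place; the steps that bear on it are the three changes of the aryl group there, which ranged from a 6.4-fold lower number from compound 1 to compound 2 (0.81 log units; beyond the scatter) to a 16-fold lower number from compound 1 to compound 3 (1.20 log units; beyond the scatter). Compound 4 is therefore expected to give a higher number in this assay, with a 10-fold higher number from compound 3 to compound 4 (1.00 log units; beyond the scatter), and an estimated 2 nM within 0.4 nM to 10 nM.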

Compound 4, inhibition constant: 5.8 nM
Beside the measured number, compound 4's estimate is 2.9-fold (0.46 log units) below it; measured number inside the range.
By their numbers in this assay, from the lowest: compound 3; then compound 2; then compounds 1 and 4 (each within the scatter of the next).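

In this assay the furan-2-yl group gives a 29-fold higher number from compound 3 to compound 4 (1.46 log units; beyond the scatter) and a 12-fold higher number from compound 2 to compound 4 (1.06 log units; beyond the scatter) while a 1.8-fold higher number from compound 1 to compound 4 (0.26 log units; within the scatter) stays within the scatter. This place therefore tolerates a wider span than the three phenyl groups showed, and the furan-2-yl compound reads level with the 4-(dimethylamino)phenyl compound, well short of the other two. No evidence at hand accounts for these steps. The compounds shown leave open how an unsubstituted phenyl or a thiophen-2-yl would read at this place, so the change of ring size and the loss of the halogens stay unseparated.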